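The source may hold more compounds than are shown below. What is called first, only, known or untested is meant among the compounds shown, and "the series" means these compounds.

Measured in a functional assay on MDA-MB-231 cells (Homo sapiens) for cytotoxicity, read by MTT assay, with a stated time of 48 h; a higher number here means a weaker inhibitor, a lower number a stronger inhibitor:
- Compound 1 `Cc1cc(Cl)ccc1NC(=O)NCCCCC(c1ccc(F)cc1)c1ccc(F)cc1`: > 20000 nM
- Compound 2 `COc1ccc(C(CCCCNC(=O)Nc2ccc(Cl)c(C(F)(F)F)c2)c2ccc(OC)cc2)cc1`: 3300 nM

The entry for compound 1, > 20000 nM, is a limit of the assay and not a number. Within the data shown here, compound 2 therefore stands alone, with 3300 nM as the only true number so far.

Compound 3 `COc1ccc(C(CCCCNC(=O)Nc2ccc(Cl)c([N+](=O)[O-])c2)c2ccc(OC)cc2)cc1` has not yet been measured. It keeps the rest of compound 2 but carries nitro in place of trifluoromethyl on an aromatic carbon, ortho to a chloro group, so that 4-chloro-3-(trifluoromethyl)phenyl becomes 4-chloro-3-nitrophenyl (nitro in place of trifluoromethyl on an aromatic carbon).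

Among the measured compounds shown here, no measured pair shows this change, so the expectation in this assay is only a cautious one: no step beyond the scatter, with a slight lean towards a weaker inhibitor. The expected step is a 1.5-fold higher number from compound 2 to compound 3 (0.18 log units; within the scatter). For compound 3 the estimated value is 5000 nM, with an expected range of 1800 nM to 15000 nM.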

Compound 3, half-maximal inhibitory concentration: 3990 nM
Beside the measured number, compound 3's estimate is 1.3-fold (0.10 log units) above it; measured number inside the range.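

Among these compounds, measured in this assay the change from trifluoromethyl to nitro on an aromatic carbon, ortho to a chloro group, gives the step of a 1.2-fold higher number from compound 2 to compound 3 (0.08 log units; within the scatter) and this is the only step that can be read. At this position, then, trifluoromethyl with 4 heavy atoms and no hydrogen-bond acceptors and nitro with 3 heavy atoms and 2 hydrogen-bond acceptors read alike in this assay, on the shared core with its two methoxy-bearing aromatic rings. Nothing at hand bears on why the two groups read alike.

The compounds shown leave open whether an amine or a carboxylic acid at this position reads the same way, and whether the result holds without the chloro group. Compound 1 differs from both in more than one place, and its entry is a limit of the assay, so it cannot be read against them.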